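Cytotoxicity series: changing the pendant ring of compound 2

The compounds below may be only part of what the source reports. "The series", "measured", "known", "first", "only" and "open" are said of these compounds alone.

Three measured compounds share one core and differ only in the ring on a carbon with a double bond to nitrogen. Compound 1 `O=C(N/N=C/c1cccc(Br)c1)Nc1cc2c(Nc3ccc(F)c(Cl)c3)ncnc2cc1O[C@H]1CCOC1` gives 32300 nM in a functional assay on HepG2 cells (Homo sapiens) for cytotoxicity, read by MTT assay, with a stated time of 72 h; a lower number here means a stronger inhibitor, a higher number a weaker inhibitor. Compound 2 `O=C(N/N=C/c1ccc([N+](=O)[O-])cc1)Nc1cc2c(Nc3ccc(F)c(Cl)c3)ncnc2cc1O[C@H]1CCOC1` gives 35300 nM in this assay, and compound 3 `COc1ccc(/C=N/NC(=O)Nc2cc3c(Nc4ccc(F)c(Cl)c4)ncnc3cc2O[C@H]2CCOC2)c(OC)c1OC` gives 29300 nM in the same assay. Compound 2 has the highest of the three numbers, but every gap to the others is within the scatter: a 1.1-fold higher number from compound 1 to compound 2 (0.04 log units; within the scatter) and a 1.2-fold lower number from compound 2 to compound 3 (0.08 log units; within the scatter), while a 1.1-fold lower number from compound 1 to compound 3 (0.04 log units; within the scatter) spans the remaining pair. No order among the three can be read from these numbers.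

Compound 4 `O=C(N/N=C/c1ccc(O)cc1O)Nc1cc2c(Nc3ccc(F)c(Cl)c3)ncnc2cc1O[C@H]1CCOC1` is not yet measured. 2,4-dihydroxyphenyl in place of 4-nitrophenyl on a carbon with a double bond to nitrogen All three measured steps exchanged this same ring at this same place, and none moved the number beyond the scatter, so the data so far give no sign that the ring governs the readout. For compound 4 the step expected is a 1.1-fold lower number from compound 2 to compound 4 (0.03 log units; within the scatter), nothing beyond the scatter. Compound 4 is therefore expected to give 33000 nM in this assay, within a range from 15000 nM to 75000 nM.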

Compound 4, half-maximal inhibitory concentration: 4530 nM
For compound 4 the middle estimate is 7.3-fold (0.86 log units) above the measured one; the whole stated range lies above it.
By their numbers in this assay, from the lowest: compound 4; then compounds 3, 1 and 2 (each within the scatter of the next).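

The position is not silent after all: in this assay, 2,4-dihydroxyphenyl on a carbon with a double bond to nitrogen gives a 7.8-fold lower number from compound 2 to compound 4 (0.89 log units; beyond the scatter) and a 6.5-fold lower number from compound 3 to compound 4 (0.81 log units; beyond the scatter) and a 7.1-fold lower number from compound 1 to compound 4 (0.85 log units; beyond the scatter), whereas exchanges among the earlier three rings stayed within the scatter. Compound 4 therefore has the lowest number of the four, separated from each of the others, and its 2,4-dihydroxyphenyl is the only ring in the set that carries hydroxyl groups. No supporting measurement is available to tie this step to any feature of the ring.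

From the compounds shown here alone, it remains open whether both hydroxyl groups are needed, which a ring with a single hydroxyl, such as 4-hydroxyphenyl or 2-hydroxyphenyl, would test, and whether 2,4-dimethoxyphenyl would keep or lose the lower number. Going by these compounds, it is equally open whether an amine or a carboxylic acid on the same ring would give a step of similar size, or whether the step is particular to hydroxyl groups.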